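Swapping a Methyl for Fluoro in a Well-Tolerated Diaryl Ether

The source may hold more compounds than are shown below. What is called first, only, known or untested is meant among the compounds shown, and "the series" means these compounds.

Compound 1 `Cc1cc(C#N)ccc1-c1ccc(Oc2ccnc(Nc3ccc(C#N)cc3)n2)c(F)c1` and compound 2 `COc1cc(-c2ccc(C#N)cc2)ccc1Oc1ccnc(Nc2ccc(C#N)cc2)n1` were tested in a functional assay on MT4 cells (Homo sapiens) for cytotoxicity, read by MTT assay, with a stated time of 5 days; a lower number here means that less compound is tolerated, a higher number that more compound is tolerated. For compound 1 the result is only a limit of the assay, > 296000 nM, as shown by the limit of > 296000 nM in this assay, at which 1 of the 2 values shown sits. For compound 2 the result is likewise only a limit, > 298000 nM, as shown by the limit of > 298000 nM in this assay, at which 1 of the 2 values shown sits. Compound 3 `N#Cc1ccc(Nc2nccc(Oc3ccc(-c4ccc(C#N)cc4F)cc3F)n2)cc1` has not yet been measured in this assay. It differs from compound 1 by fluoro in place of methyl on an aromatic carbon. Both measured values sit at a limit, so the step that the limit leaves unreadable from compound 1 to compound 3 is expected to stay within the scatter. Compound 3 is therefore expected to give about 300000 nM, in a range from 100000 nM to 600000 nM.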

Compound 3, half-maximal cytotoxic concentration: > 294000 nM
Compound 3: only a limit was reported; the forecaster's own chance of this, stated with the estimate: 85%; the middle value does not contradict the limit.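

Within the data shown here, compound 1 and compound 3 each gave only a limit, so no step between them can be read. The compounds shown leave open whether fluoro in place of methyl changes how much compound the cells tolerate.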